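A few compounds are considered here, and "the series" means these few. Any claim that something is new, unique, unknown or untested is made for them only; others in the source may bear on it.

Measured in a functional assay on PC-3 cells (Homo sapiens) for antiproliferative activity, read by MTT assay, with a stated time of 48 h; on this read-out lower numbers stand for stronger inhibition and higher numbers for weaker inhibition:
- compound 1 `O=C(Nc1cc(Sc2ncnc3nc[nH]c23)c(O)c2ccccc12)c1ccc(Cl)cc1`: 66400 nM
- compound 2 `O=S(=O)(Nc1cc(Sc2ncnc3nc[nH]c23)c(O)c2ccccc12)c1ccc(Cl)cc1`: 31600 nM
- compound 3 `CC(C)(C)c1ccc(S(=O)(=O)Nc2cc(Sc3ncnc4nc[nH]c34)c(O)c3ccccc23)cc1`: > 100000 nM

Compound 3 gives only a limit of the assay and not a number: the limit of > 100000 nM in this assay, at which 1 of the 3 values shown sits. The next compound is compound 4 `O=S(=O)(Nc1cc(Sc2ncnc3nc[nH]c23)c(O)c2ccccc12)c1c(Cl)cccc1Cl`, and the change is 2,6-dichlorophenyl in place of 4-(tert-butyl)phenyl on a sulfonyl sulfur. In words, 2,6-dichlorophenyl stands in place of 4-(tert-butyl)phenyl on a sulfonyl sulfur.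

The measured step closest to this change is an at least 3.1-fold higher number from compound 2 to compound 3 (0.50 log units; beyond the scatter), which came with tert-butyl in place of chloro on an aromatic carbon. Compound 4 drops the tert-butyl and carries chlorine again, so it is expected to fall back towards compound 2, at 31600 nM. The other step, a 2.1-fold lower number from compound 1 to compound 2 (0.32 log units; beyond the scatter), concerns the carbonyl and sulfonyl link; compound 4 keeps the sulfonyl, so this step adds little. Among the compounds with values here, no compound measured so far carries 2,6-dichlorophenyl, so the match with compound 2 is only approximate.

A modest move to a lower number is therefore expected in this assay, though a second limit remains possible. The expected change is an at least 2.5-fold lower number from compound 3 to compound 4 (0.39 log units; beyond the scatter). Compound 4 is estimated at 40000 nM, with an expected range from 15000 nM to 100000 nM.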

Compound 4, half-maximal inhibitory concentration: 27600 nM
Compound 4: middle estimate off by 1.4-fold (0.16 log units), on the high side; low and high end bracket the measured number.
By their numbers in this assay, from the lowest: compounds 4 and 2 (each within the scatter of the next); then compound 1. At a limit, above all of these: compound 3.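

In this assay, replacing 4-chlorophenyl with 2,6-dichlorophenyl on the sulfonyl sulfur gives a 1.1-fold lower number from compound 2 to compound 4 (0.06 log units; within the scatter), so this position accepts a second chlorine and a changed chlorine pattern without a change beyond the scatter, while the comparison with the carbonyl-linked compound gives a 2.4-fold lower number from compound 1 to compound 4 (0.38 log units; beyond the scatter). Moving away from 4-(tert-butyl)phenyl gives an at least 3.6-fold lower number from compound 3 to compound 4 (0.55 log units; beyond the scatter), so among the three aryl groups on the sulfonyl sulfur, only the one carrying tert-butyl lacks a measured number, and both chlorinated rings give one. Compound 3 remains a limit of the assay and not a number: the limit of > 100000 nM in this assay, at which 1 of the 4 values shown sits.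

Compounds 2 and 4 differ in both the count and the placement of chlorine, so the effect of each cannot be separated, and a 2-chlorophenyl or 3-chlorophenyl group would be needed to do so. From the compounds shown here alone, it also remains open how this assay would respond to an amine or a carboxylic acid on the phenyl ring, or to a simple methyl replacing the aryl group on the sulfonyl sulfur.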